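Series notes: biaryl amides, propyl to acetamido exchange

The compounds below may be only part of what the source reports. "The series", "measured", "known", "first", "only" and "open" are said of these compounds alone.

Measured so far:
- compound 1, `CC[C@H](C)[C@H](N)CN(C(=O)[C@@H]1C[C@H]1c1ccsc1)c1ccc(-c2ccccc2)cc1`: 450 nM
- compound 2, `CC(C)C[C@H](N)CN(C(=O)[C@@H]1C[C@H]1c1ccccc1)c1ccc(-c2ccccc2F)cc1`: 1600 nM
- compound 3, `CCCc1ccc(-c2ccc(N(C[C@@H](N)[C@@H](C)CC)C(=O)[C@@H]3C[C@H]3c3ccccc3)cc2)cc1`: 61 nM

In a functional assay for agonist activity at G protein-coupled receptor 88 (Homo sapiens), read by HTRF and cAMP accumulation (on this read-out lower numbers stand for an effect already at smaller amounts and higher numbers for an effect only at larger amounts of compound), compound 3 gives 61 nM, the lowest of the three numbers. Compound 1 stands next with 450 nM, a gap that is beyond the scatter; compound 2 is furthest with 1600 nM, also beyond the scatter. On these three numbers compound 3 is the most active of the set.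

Compound 4, `CC[C@H](C)[C@H](N)CN(C(=O)[C@@H]1C[C@H]1c1ccccc1)c1ccc(-c2ccc(NC(C)=O)cc2)cc1`, follows from compound 3 by one change: acetamido in place of propyl on an aromatic carbon. Within the data shown here, no measured pair in the set shows this exchange, so the size of the step cannot be read from a recorded difference; the two other compounds differ from compound 3 in more than one place and carry no acetamido.

Expectation for this assay: a step from compound 3 to compound 4 toward higher numbers, moderate in size and beyond the scatter, as read from the estimate a 4.9-fold higher number from compound 3 to compound 4 (0.69 log units; beyond the scatter). Compound 4 is estimated to give 300 nM in this assay, with the likely span taken as 90 nM to 1000 nM.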

Compound 4, half-maximal effective concentration: 5500 nM
Compound 4: middle estimate off by 18-fold (1.26 log units), on the low side, and the stated range ends below it.
By their numbers in this assay, from the lowest: compound 3; then compound 1; then compound 2; then compound 4.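

In this assay, among these compounds, the aromatic position para to a large group proves far from indifferent to what it carries: the change from 4-propylphenyl to 4-acetamidophenyl gives a 90-fold higher number from compound 3 to compound 4 (1.96 log units; beyond the scatter) and is the first single change that can be read directly, as the earlier compounds offered no pair differing in one place. The change is not a clean test of one feature, since acetamido brings 1 hydrogen-bond donor and 1 hydrogen-bond acceptor where propyl has neither, and it also differs from propyl in its atoms and its double bond. Nothing at hand bears on why the number rises this far, so the step stands as an observation only.

Which of these differences carries the step stays open: a methoxy group, a primary amine or a butyl chain at this position would help separate the contributions of the amide hydrogen, the carbonyl and chain length. Going by these compounds, whether a step of this size holds on other members also stays open, as the exchange is seen only once, between compound 3 and compound 4.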